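Ring Size and Chloro Loss in a Small Amide Series

A few compounds are considered here, and "the series" means these few. Any claim that something is new, unique, unknown or untested is made for them only; others in the source may bear on it.

Compound 1 `CCN(C(=O)CC(CC(=O)NCCN1CCCCC1)c1ccc(Cl)cc1)C1Cc2ccccc2C1`: 21200 nM
Compound 2 `CCN(C(=O)CC(CC(=O)NCCN1CCCC1)c1ccc(Cl)cc1)C1Cc2ccccc2C1`: 55500 nM
Compound 3 `CCN(C(=O)CC(CC(=O)NCCN1CCCC1)c1ccccc1)C1Cc2ccccc2C1`: > 100000 nM

Of the compounds shown here, three have been measured in a functional assay on MGC-803 cells (Homo sapiens) for inhibition; a lower number here means a stronger inhibitor, a higher number a weaker inhibitor. Compound 1 gives 21200 nM, and compound 2 gives 55500 nM. For compound 3 the value > 100000 nM is a limit of this assay and not a number; compound 3 stands at the limit of > 100000 nM in this assay, at which 1 of the 3 values shown sits.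

Compound 2 and compound 1 differ by piperidin-1-yl in place of pyrrolidin-1-yl on a saturated chain carbon, two bonds along the chain from an amide-type nitrogen, and that change gave a 2.6-fold lower number from compound 2 to compound 1 (0.42 log units; beyond the scatter). The cores of compound 2 and compound 3 differ by hydrogen in place of chloro on an aromatic carbon, with a step of an at least 1.8-fold higher number from compound 2 to compound 3 (0.25 log units; that floor lies within the scatter).

Compound 4 `CCN(C(=O)CC(CC(=O)NCCN1CCCCC1)c1ccccc1)C1Cc2ccccc2C1` has not yet been measured in this assay. It differs from compound 3 by piperidin-1-yl in place of pyrrolidin-1-yl on a saturated chain carbon, two bonds along the chain from an amide-type nitrogen, the same change made from compound 2 to compound 1, at the same place. The step from compound 3 to compound 4 is expected to be about an at least 1.2-fold lower number from compound 3 to compound 4 (0.09 log units; that floor lies within the scatter), resting on the step of a 2.6-fold lower number from compound 2 to compound 1 (0.42 log units; beyond the scatter). Because compound 3 shows only a limit, > 100000 nM, the starting point is uncertain. Compound 4 is therefore estimated at 80000 nM, between 30000 nM and 250000 nM, with a real chance that it too only reaches a limit.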

Compound 4, half-maximal inhibitory concentration: > 100000 nM
Compound 4: no number, only a limit; the forecaster's own chance of this, stated with the estimate: 45%; middle value at least 1.2-fold (0.09 log units) away from the limit.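

In this assay compound 4 gives > 100000 nM as a limit of the assay and not a number. The step from compound 3 to compound 4 cannot be read, so the change from pyrrolidin-1-yl to piperidin-1-yl, which gave a 2.6-fold lower number from compound 2 to compound 1 (0.42 log units; beyond the scatter) on the chloro core, is neither confirmed nor refuted on the core without chloro. Hydrogen in place of chloro, now seen on the piperidin-1-yl core as an at least 4.7-fold higher number from compound 1 to compound 4 (0.67 log units; beyond the scatter) in the same direction as on the pyrrolidin-1-yl core, cannot be said to have the same size on both: the same change on two cores in this assay, an at least 1.8-fold higher number (0.25 log units; that floor lies within the scatter) from compound 2 to compound 3 and an at least 4.7-fold higher number (0.67 log units; beyond the scatter) from compound 1 to compound 4; the limit leaves it open whether they differ.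

The compounds shown leave open how far compound 3 and compound 4 lie past the limit, and so whether the ring change has any effect without the chloro. They also leave open whether fluoro or bromo in place of chloro, or a dimethylamino group in place of the ring, would give a readable number in this assay on this core.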